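Replacing a Phenolic Hydroxy with a Carboxylic Acid

This account rests on a few compounds, and the source may have more. Where it says the series, first, only, none or still open, it means among the compounds named here.

Of the compounds shown here, two have so far been tested in an assay on isolated protein for inhibition of Alpha-amylase 1A (Homo sapiens), read by spectrophotometry; a lower number here means a stronger inhibitor, a higher number a weaker inhibitor. Compound 1, `Oc1ccc(Nc2nc(-c3ccc(O)cc3O)cs2)cc1`, gives 138000 nM and holds the lower of the two numbers. Compound 2, `C/C(=N\NC(=O)CCC(=O)Nc1ccccc1C)c1ccc(O)cc1O`, is built on a different core and gives 850000 nM, a higher number whose gap to compound 1 lies beyond the usual scatter, so compound 1 is the stronger inhibitor of the pair. Compound 3, `O=C(O)c1ccc(Nc2nc(-c3ccc(O)cc3O)cs2)cc1`, keeps the core of compound 1 and differs in only one place: carboxy in place of hydroxy on an aromatic carbon. For the measured compounds named here, no measured pair shows what this exchange does on this core, so the expectation rests on compound 1 alone. The expected step is a 1.3-fold lower number from compound 1 to compound 3 (0.10 log units; within the scatter), meaning no shift beyond the usual scatter in either direction. For compound 3 the estimated value in this assay is 110000 nM, with a likely range from 30000 nM to 400000 nM.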

Compound 3, half-maximal inhibitory concentration: 680000 nM
Estimate against measurement, compound 3: 6.2-fold (0.79 log units) below; measured number above the stated range.
By their numbers in this assay, from the lowest: compound 1; then compounds 3 and 2 (each within the scatter of the next).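

For the compounds shown here, this is the first pair measured on the shared core, and it shows that the position para to a large group is sensitive to what sits there. In this assay, carboxy in place of hydroxy on this aromatic carbon gives a 4.9-fold higher number from compound 1 to compound 3 (0.69 log units; beyond the scatter) and so weakens inhibition, which means the hydroxy of compound 1 cannot be exchanged for carboxy here without a loss. Going by these compounds alone, nothing measured so far explains why the number rises.

One exchange at one position cannot tell whether the loss comes with carboxy alone or with any replacement of the hydroxy. A methoxy, an amine or a methyl ester at this position would help to separate those two readings, and each could equally match compound 1 or fall short of it.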